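The source may hold more compounds than are shown below. What is called first, only, known or untested is meant among the compounds shown, and "the series" means these compounds.

Of the compounds shown here, three that share one core have been tested in a functional assay on A549 cells (Homo sapiens) for antiproliferative activity, read by MTT assay, with a stated time of 72 h; on this read-out lower numbers stand for stronger inhibition and higher numbers for weaker inhibition. Compound 1 `O=C(Nc1ccc(Cl)c(-c2nnc3c(Cl)cccn23)c1)c1ccc(C(F)(F)F)cc1Cl` reaches only a limit of the assay, > 100000 nM. Compound 2 `O=C(Nc1ccc(Cl)c(-c2nnc3c(Cl)cccn23)c1)c1ccccn1` likewise reaches only a limit, > 100000 nM. Compound 3 `O=C(Nc1ccc(Cl)c(-c2nnc3c(Cl)cccn23)c1)c1ccc(C(F)(F)F)cc1F` also stops at a limit, > 100000 nM. Compound 2 therefore stands where everything measured so far stands, at the limit of > 100000 nM in this assay, at which 3 of the 3 values shown sit. Among the compounds with values here, the one step between measured neighbours, a step that the two limits leave unreadable from compound 1 to compound 3, cannot be read for the same reason. Compound 4 `O=C(Nc1ccc(Cl)c(-c2nnc3c(Cl)cccn23)c1)c1cccc(Cl)c1` differs from compound 2 by 3-chlorophenyl in place of pyridin-2-yl on a carbonyl carbon. Within the data shown here, no measured step tracks this change, so nothing points to a move away from the limit. The step is expected to be a number no higher from compound 2 to compound 4 (the limit leaves the size open). Compound 4 is estimated at 100000 nM, in a range from 30000 nM to 300000 nM.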

Compound 4, half-maximal inhibitory concentration: 52700 nM
Compound 4: the middle estimate sits 1.9-fold (0.28 log units) above what was measured; the range from low to high includes it.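

Replacing pyridin-2-yl with 3-chlorophenyl on the carbonyl carbon gives, in this assay, an at least 1.8-fold lower number from compound 2 to compound 4 (0.27 log units; that floor lies within the scatter). This is only a floor, so the change may be small or much larger, and the true size cannot be read. Still, this position is the first place in the series where a change brings a value inside the measurable range, while the other compounds stay at the assay's limit: the limit of > 100000 nM in this assay, at which 3 of the 4 values shown sit.

On these data alone, whether a plain phenyl would do the same remains open, since this change alters both the ring atoms and the chlorine. So does the effect of an amine or a carboxylic acid on that ring.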